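The source may report more compounds than this note shows. Statements on the series, on what has been measured and on what is new or still open speak of the compounds shown alone.

Compound 3 `Cc1ccc(NC(=S)N/N=C/c2ccc3ccccc3n2)cc1` was tested in a functional assay on HT-29 cells (Homo sapiens) for antiproliferative activity, read by sulforhodamine B assay, with a stated time of 72 h (a lower number here means a stronger inhibitor, a higher number a weaker inhibitor), where compound 3 gives 85500 nM. Compound 1 `N#Cc1ccc(NC(=S)N/N=C/c2ccc3ccccc3n2)cc1` gives 15600 nM in this assay, so compound 3 sits highest of the two numbers; the gap is a 5.5-fold higher number from compound 1 to compound 3 (0.74 log units; beyond the scatter). Compound 2 `S=C(N/N=C/c1ccc2ccccc2n1)Nc1ccccc1Br` returns only a limit in this assay, > 100000 nM (the limit of > 100000 nM in this assay, at which 1 of the 3 values shown sits). A further step is an at least 1.1-fold lower number from compound 2 to compound 3 (0.06 log units; that floor lies within the scatter). Compound 4 `S=C(NCc1ccccc1)N/N=C/c1ccc2ccccc2n1` has the same atoms as compound 3, joined differently: benzyl in place of 4-methylphenyl on an amide-type nitrogen. The two steps that swap a group on that nitrogen, a 5.5-fold higher number from compound 1 to compound 3 (0.74 log units; beyond the scatter) and an at least 1.1-fold lower number from compound 2 to compound 3 (0.06 log units; that floor lies within the scatter), were modest or within the scatter, yet neither involves benzyl, so no step beyond the scatter is expected in this assay. Compound 4 is estimated at 80000 nM, between 20000 nM and 200000 nM, meaning a 1.1-fold lower number from compound 3 to compound 4 (0.03 log units; within the scatter).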

Compound 4, half-maximal inhibitory concentration: 75700 nM
For compound 4 the middle estimate is 1.1-fold (0.02 log units) above the measured one, within the range that was stated.
By their numbers in this assay, from the lowest: compound 1; then compounds 4 and 3 (each within the scatter of the next). At a limit, above all of these: compound 2.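

In this assay, benzyl in place of 4-methylphenyl on an amide-type nitrogen rearranges the same atoms and gives a 1.1-fold lower number from compound 3 to compound 4 (0.05 log units; within the scatter). Benzyl also stays apart from 4-cyanophenyl, at a 4.9-fold higher number from compound 1 to compound 4 (0.69 log units; beyond the scatter), so compound 1 alone has the lower number. Benzyl in place of 2-bromophenyl can be read only as a floor: an at least 1.3-fold lower number from compound 2 to compound 4 (0.12 log units; that floor lies within the scatter). Compound 2 gives only a limit: the limit of > 100000 nM in this assay, at which 1 of the 4 values shown sits.

Going by these compounds, whether a nitrile on the benzyl ring would bring the number down remains open, as does the effect of a longer chain such as phenylethyl or of an amine on that nitrogen.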